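Swapping bromo for iodo on the shared core

A few compounds are considered here, and "the series" means these few. Any claim that something is new, unique, unknown or untested is made for them only; others in the source may bear on it.

Compound 1 `O=C1C(Nc2ccc(F)cc2)=CC(=O)c2ncccc21`: 541 nM
Compound 2 `O=C1C(Nc2ccc(Cl)cc2)=CC(=O)c2ncccc21`: 178 nM
Compound 3 `O=C1C(Nc2ccc(Br)cc2)=CC(=O)c2ncccc21`: 302 nM

All three values come from a functional assay (aorta) for inhibition, with Rattus norvegicus as the target (on this read-out lower numbers stand for an effect already at smaller amounts and higher numbers for an effect only at larger amounts of compound), and show a modest spread. Compound 3 stands within the scatter of both other compounds, with a 1.7-fold higher number from compound 2 to compound 3 (0.23 log units; within the scatter) on one side and a 1.8-fold lower number from compound 1 to compound 3 (0.25 log units; within the scatter) on the other. Only a 3.0-fold lower number from compound 1 to compound 2 (0.48 log units; beyond the scatter) goes beyond the scatter of the measurement.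

Compound 4 `O=C1C(Nc2ccc(I)cc2)=CC(=O)c2ncccc21`, not yet measured, carries iodo in place of bromo on an aromatic carbon. The three measured steps all exchange one halogen for another at this same place, so they are the evidence that bears on it. The closest in kind, a 1.7-fold higher number from compound 2 to compound 3 (0.23 log units; within the scatter), stayed within the scatter, while the largest was still modest. No step beyond the scatter is therefore expected, and the estimate means a 1.0-fold lower number from compound 3 to compound 4 (0.02 log units; within the scatter) as the expected change. Compound 4 is estimated at 290 nM in this assay, with an expected range from 120 nM to 700 nM for the coming measurement.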

Compound 4, half-maximal effective concentration: 214 nM
Compound 4: middle estimate off by 1.4-fold (0.13 log units), on the high side, within the range that was stated.
By their numbers in this assay, from the lowest: compounds 2, 4, 3 and 1 (each within the scatter of the next, the first and the last beyond it).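

In this assay, iodo on an aromatic carbon, para to a large group, cannot be told apart from the two heavier halogens before it, as both (a 1.4-fold lower number from compound 3 to compound 4 (0.15 log units; within the scatter)) and (a 1.2-fold higher number from compound 2 to compound 4 (0.08 log units; within the scatter)) stay within the scatter, so chloro, bromo and iodo now read as one level at this position. The change from fluoro to iodo (a 2.5-fold lower number from compound 1 to compound 4 (0.40 log units; beyond the scatter)) gives a second step beyond the scatter alongside the one from fluoro to chloro, though compound 3 goes against a clean split, since its step from compound 1 stays within the scatter. No measurement at hand offers an explanation for these differences.

On these data alone, all four compounds carry a halogen here, so it stays open how an amine, a methoxy group or a carboxylic acid at this place would read in this assay. Changes to the shared core, with the halogen held fixed, also remain open.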